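The source may hold more compounds than are shown below. What is called first, only, known or untested is meant among the compounds shown, and "the series" means these compounds.

Measured in a functional assay on MCF7 cells (Homo sapiens) for inhibition, in the absence of a further agent; on this read-out higher numbers stand for weaker inhibition and lower numbers for stronger inhibition:
- compound 1 `COc1ccc(N)c2c(=O)cc(-c3ccc(N)cc3)oc12`: 21000 nM; 19000 nM (2 entries)
- compound 2 `Nc1ccc(-c2cc(=O)c3c(N)cccc3o2)cc1`: 7.3 nM

Within the data shown here, the single number for compound 2, 7.3 nM, lies far below the entries of compound 1; a further entry for compound 2 carries no number. Compound 3 `Nc1ccc(-c2cc(=O)c3c(N)ccc(O)c3o2)cc1` has hydroxy in place of hydrogen on an aromatic carbon of compound 2 (hydroxy in place of hydrogen on an aromatic carbon). Among the measured compounds shown here, no measured pair isolates this change, but compound 1, also substituted on that ring, gives 21000 nM; 19000 nM (2 entries), so a large move towards weaker inhibition in this assay is expected. The expected change is a 210-fold higher number from compound 2 to compound 3 (2.31 log units; beyond the scatter). For compound 3 the estimated value is 1500 nM, with an expected range from 100 nM to 20000 nM.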

Compound 3, half-maximal inhibitory concentration: 5300 nM
Compound 3: the middle estimate sits 3.5-fold (0.55 log units) below what was measured, within the range that was stated.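

Hydroxy in place of hydrogen on this aromatic carbon, para to an amino group, brings a 730-fold higher number from compound 2 to compound 3 (2.86 log units; beyond the scatter) in this assay. This gives the first direct measure of a change at this position, and it shows that the large move towards weaker inhibition is not confined to the methoxy group of compound 1. The number of compound 3 still lies below those of compound 1, whose entries agree closely: the several entries of compound 1 in this assay, 21000 nM; 19000 nM (2 entries)

The compounds shown leave open how fluorine, an amine or a carboxylic acid on this carbon would read in this assay.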